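The source may hold more compounds than are shown below. What is called first, only, known or untested is meant among the compounds shown, and "the series" means these compounds.

In a functional assay on SUP-B15 cells (Homo sapiens) for antiproliferative activity, with a stated time of 72 h (a lower number here means that less compound is needed, a higher number that more compound is needed for the effect), compound 1 `COc1ccc(-c2cc(=O)c3c(OC)cc(OC)cc3n2Cc2ccccc2)cc1` is recorded only as a limit, > 34400 nM, and this is the limit described as the limit of > 34400 nM in this assay, at which 1 of the 3 values shown sits. Going by the values given here, compound 2 `C=CCNC(=O)n1c(-c2ccc(OC)cc2)cc(=O)c2c(OC)cc(OC)cc21` gives 16000 nM, and the step of an at least 2.1-fold lower number from compound 1 to compound 2 (0.33 log units; beyond the scatter) is the only change measured in one place. Compound 3 `COc1ccc(-c2cc(=O)c3c(OC)cc(OC)cc3n2S(=O)(=O)c2c(F)c(F)c(F)c(F)c2F)cc1` gives 4100 nM, the lowest of the two numbers in this assay; the nearest value is that of compound 2, which stands higher, beyond the scatter.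

Compound 4 `COc1ccc(-c2cc(=O)c3c(OC)cc(OC)cc3n2S(=O)(=O)c2ccc(OC)cc2)cc1` differs from compound 3 by 4-methoxyphenyl in place of 2,3,4,5,6-pentafluorophenyl on a sulfonyl sulfur. Among the compounds with values here, no measured step touches the group on the sulfonyl sulfur; the one measured step, from compound 1 to compound 2, alters the substituent on the aromatic nitrogen instead, so it offers no guide here. A step of no more than the scatter is therefore expected, in either direction. Compound 4 is expected to give about 5000 nM in this assay, between 1500 nM and 16000 nM. Compound 4 is thus estimated to show a step of a 1.2-fold higher number from compound 3 to compound 4 (0.09 log units; within the scatter) from compound 3.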

Compound 4, half-maximal effective concentration: > 82700 nM
Compound 4: no number, only a limit; the forecaster's own chance of this, stated with the estimate: 10%; middle value at least 16-fold (1.21 log units) away from the limit.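

In this assay, 4-methoxyphenyl in place of 2,3,4,5,6-pentafluorophenyl on a sulfonyl sulfur gives an at least 20-fold higher number from compound 3 to compound 4 (1.30 log units; beyond the scatter), so the group on the sulfonyl sulfur, which the earlier step did not touch, matters greatly here. The sulfonyl link alone does not secure a low number: (4-methoxyphenyl)sulfonyl in place of allylcarbamoyl on an aromatic nitrogen gives an at least 5.1-fold higher number from compound 2 to compound 4 (0.71 log units; beyond the scatter). Compound 4 is recorded only as a limit, and with compound 1 also a limit, the step between those two cannot be read: the limit of > 82700 nM in this assay, at which 1 of the 4 values shown sits.

The compounds shown do not separate the loss of the fluorine atoms from the entry of the methoxy group, and no measured property accounts for the step. On these data alone, how a phenyl ring carrying an amine or a carboxylic acid, or a plain alkyl chain, would behave on the sulfonyl sulfur in this assay stays open.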